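The source may report more compounds than this note shows. Statements on the series, on what has been measured and on what is new or still open speak of the compounds shown alone.

In an assay on Sf9 cells for inhibition of protein deacetylase HDAC6 (Homo sapiens), read by fluorescence, with stated times of 90 min and 30 min (on this read-out lower numbers stand for stronger inhibition and higher numbers for weaker inhibition), compound 1 `Cc1ccc(NC(=O)CCN(Cc2ccc(C(=O)NO)cc2)C(=O)c2cc(C)cc(C)c2)cc1` gives 31.1 nM, the highest of the three numbers in hand. Compound 3 `COc1cc(OC)cc(C(=O)N(CCC(=O)NCc2ccccc2)Cc2ccc(C(=O)NO)cc2)c1` gives 26 nM, which lies within the usual scatter of the value of compound 1, while compound 2 `Cc1ccc(CNC(=O)CCN(Cc2ccc(C(=O)NO)cc2)C(=O)c2ccc(N(C)C)cc2)cc1` gives 14.4 nM, a lower number that lies beyond the scatter. Compound 4 `Cc1ccc(NC(=O)CCN(Cc2ccc(C(=O)NO)cc2)C(=O)c2ccccc2)cc1` differs from compound 1 in one place: phenyl in place of 3,5-dimethylphenyl on a carbonyl carbon, so that the (3,5-dimethylphenyl)carbonyl becomes a benzoyl. Among the compounds with values here, no pair of measured compounds shows this change on its own, so there is no direct precedent for it. The expected step of a 1.4-fold higher number from compound 1 to compound 4 (0.16 log units; within the scatter) is small, and a slight weakening that stays within the scatter seems the likeliest outcome. Compound 4 is therefore expected to give 45 nM, with a range from 20 nM to 110 nM.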

Compound 4, half-maximal inhibitory concentration: 10.7 nM
Beside the measured number, compound 4's estimate is 4.2-fold (0.62 log units) above it, outside the stated range (below it).
By their numbers in this assay, from the lowest: compounds 4, 2, 3 and 1 (each within the scatter of the next, the first and the last beyond it).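

In this assay, the phenyl in place of 3,5-dimethylphenyl on a carbonyl carbon gives a 2.9-fold lower number from compound 1 to compound 4 (0.46 log units; beyond the scatter) and so shows that this position responds to the group it carries, with the two methyl groups costing inhibition in this series. The earlier compounds shown here differed in more than one place and could not show this. Nothing measured here explains the step. From the compounds shown here alone, whether a pyridine ring or a fluorine on the phenyl would keep the lower number stays open, as does whether removing the methyl groups does the same on the other side chains.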